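The source may hold more compounds than are shown below. What is called first, only, known or untested is meant among the compounds shown, and "the series" means these compounds.

Compound 1 `Cc1cc(OC[C@@H]2CN(C)c3ccccc3O2)ccc1C(=O)n1c(C)c(CC(=O)O)c2cc(F)ccc21` was tested in a functional assay on CHO cells for antagonist activity at prostaglandin D2 receptor (Mus musculus), read by cAMP accumulation and immunoassay, with a stated time of 10 min, in the presence of a further agent that is not named here (a lower number here means a stronger inhibitor, a higher number a weaker inhibitor), where compound 1 gives 3.2 nM. Among the measured compounds shown here, the only other measured compound, compound 2 `Cc1c(CC(=O)O)c2cc(F)ccc2n1C(=O)c1ccc(OC[C@@H]2CN(C)c3ccccc3O2)cc1Cl`, gives 1.6 nM in this assay, and the step of a 2.0-fold lower number from compound 1 to compound 2 (0.30 log units; within the scatter) lies within the scatter, so the two stand together. Compound 3 `Cc1cc(OC[C@@H]2COc3ccccc32)ccc1C(=O)n1c(C)c(CC(=O)O)c2cc(F)ccc21` differs from compound 1 by a group of 9 heavy atoms (8 carbon, 1 oxygen; one five-membered non-aromatic ring with 1 hetero atom, one six-membered aromatic ring of carbon only) in place of a group of 11 heavy atoms (9 carbon, 1 nitrogen, 1 oxygen; one six-membered non-aromatic ring with 2 hetero atoms, one six-membered aromatic ring of carbon only), on a saturated chain carbon bound to an oxygen on an aromatic ring. For the measured compounds named here, no measured step touches this part of the molecule; the chloro-for-methyl step is the only one available and does not bear on it. The estimate for compound 3 is therefore a cautious one of 5 nM (range 1.5 nM to 20 nM), the expected step being a 1.6-fold higher number from compound 1 to compound 3 (0.19 log units; within the scatter).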

Compound 3, half-maximal inhibitory concentration: 1.8 nM
Estimate against measurement, compound 3: 2.8-fold (0.44 log units) above; the range from low to high includes it.
By their numbers in this assay, from the lowest: compounds 2, 3 and 1 (each within the scatter of the next).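

In this assay the change at this saturated chain carbon bound to an oxygen on an aromatic ring gives a 1.8-fold lower number from compound 1 to compound 3 (0.25 log units; within the scatter). The six-membered non-aromatic ring with 2 hetero atoms, and with it the nitrogen, can therefore give way to the five-membered ring with 1 hetero atom while the two compounds still stand together. No measurement is available to explain why these two groups read alike. From the compounds shown here alone, whether the aromatic ring in these groups is needed stays open, and a cyclohexyl group at this carbon would test that. Going by these compounds, the opposite configuration at the defined stereocentre also stays open.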